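From a Fluorophenyl Amine to an Ethyl Urea

The source may report more compounds than this note shows. Statements on the series, on what has been measured and on what is new or still open speak of the compounds shown alone.

Among the three measured compounds, compound 2 `Cn1cc(-c2ncc(C#N)c(N3C[C@@H]4C[C@H]3CN4c3cccc(F)c3)n2)cn1` stands lowest in a physicochemical assay for lipophilicity, read by HPLC; on this read-out lower numbers stand for lower lipophilicity and higher numbers for higher lipophilicity: compound 2 gives 3.1. In this assay compound 1 `N#Cc1cnc(-c2ccccc2)nc1N1C[C@@H]2C[C@H]1CN2c1cccc(F)c1` gives 4.5, and compound 3 `N#Cc1cnc(-c2ccnc3[nH]ccc23)nc1N1C[C@@H]2C[C@H]1CN2c1cccc(F)c1` gives 3.4. The step of a number 1.40 log units lower from compound 1 to compound 2 (beyond the scatter) and the step of a number 1.10 log units lower from compound 1 to compound 3 (beyond the scatter) both lie beyond the scatter, whereas a number 0.30 log units higher from compound 2 to compound 3 (within the scatter) lies within it. Compound 4 `CCNC(=O)N1C[C@@H]2C[C@H]1CN2c1nc(-c2cnn(C)c2)ncc1C#N` differs from compound 2 at a different site: ethylcarbamoyl in place of 3-fluorophenyl on an amine nitrogen in a ring. Going by the values given here, none of the measured steps touches this amine nitrogen; all three change the group on the aromatic carbon, so no measured step bears directly on the new change. What the change itself shows is that a ring of carbon only with one fluorine leaves, and a group without a ring, carrying one hydrogen-bond donor and one hydrogen-bond acceptor, enters. On that basis a downward step beyond the scatter is expected, namely a number 1.60 log units lower from compound 2 to compound 4 (beyond the scatter). Compound 4 is therefore estimated at 1.5, with a range from 0.8 to 2.2.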

Compound 4, distribution coefficient: 0.8
Beside the measured number, compound 4's estimate is 0.70 log units above it, within the range that was stated.
By their numbers in this assay, from the lowest: compound 4; then compounds 2 and 3 (each within the scatter of the next); then compound 1.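

Going by these compounds alone, the amine nitrogen in the ring, untouched by the earlier steps, proves to be a site where a single change moves this assay a long way: ethylcarbamoyl in place of 3-fluorophenyl gives a number 2.30 log units lower from compound 2 to compound 4 (beyond the scatter). Within the data shown here, this exceeds a number 1.40 log units lower from compound 1 to compound 2 (beyond the scatter), the largest of the earlier steps, all of which changed the group on the aromatic carbon. Nothing shown here accounts for the size of this step.

The data do not separate the 3-fluorophenyl group that leaves from the ethylcarbamoyl group that enters. An acetyl group, a methylcarbamoyl group or a longer chain on the same nitrogen would bear on this question. On these data alone, it is also open whether the same exchange would give a step of similar size with the phenyl of compound 1 on the aromatic carbon.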